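A few compounds are considered here, and "the series" means these few. Any claim that something is new, unique, unknown or untested is made for them only; others in the source may bear on it.

Measured so far:
- compound 1, `CCCc1cc(N)c2cc(NC(=O)c3ccc(C(F)(F)F)cc3)ccc2n1`: 10000 nM
- compound 2, `CCCc1cc(N)c2cc(NC(=O)/C=C/c3ccc(C(C)C)cc3)ccc2n1`: 2.9 nM

In an assay on isolated protein for displacement of a labelled ligand from melanin-concentrating hormone receptor 1 (Homo sapiens) (a higher number here means a weaker inhibitor, a lower number a stronger inhibitor), compound 1 gives 10000 nM, the highest of the two numbers shown, while compound 2 gives 2.9 nM, far lower. Compound 3, `CCCc1cc(N)c2cc(NC(=O)c3ccc(-c4ccc(Cl)cc4)cc3)ccc2n1`, is not yet measured. It differs from compound 1 by 4-chlorophenyl in place of trifluoromethyl on an aromatic carbon. Among the measured compounds shown here, no measured pair shows this exact change, so the expected size rests on compound 2, whose far lower number shows that a larger group in this position can go with much stronger binding. A large step downward is expected, a 330-fold lower number from compound 1 to compound 3 (2.52 log units; beyond the scatter). For compound 3 the estimate is 30 nM, within 3 nM to 300 nM.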

Compound 3, half-maximal inhibitory concentration: 0.7 nM
Compound 3: the middle estimate sits 43-fold (1.63 log units) above what was measured; the measured number lies below the stated range.
By their numbers in this assay, from the lowest: compound 3; then compound 2; then compound 1.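

In this assay the change from trifluoromethyl to 4-chlorophenyl gives a 14000-fold lower number from compound 1 to compound 3 (4.15 log units; beyond the scatter) and so shows that one group, para to a large group, can separate a very weak inhibitor from a very strong one. The earlier compounds shown here differed in more than one place and could not show this. Nothing here measures why the step is so large.

On these data alone, it remains open whether the chlorine matters or the added ring alone is enough. Plain phenyl, or a 4-aminophenyl group, at this position would help separate the two.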